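A few compounds are considered here, and "the series" means these few. Any claim that something is new, unique, unknown or untested is made for them only; others in the source may bear on it.

Compounds measured so far:
- compound 1, `COc1cc2c(cc1OC)C(=O)C(CC1CCN(C(=S)Nc3ccccc3)CC1)C2`: 300 mg/kg
- compound 2, `COc1cc2c(cc1OC)C(=O)C(CC1CCN(C(=S)Nc3ccccc3[N+](=O)[O-])CC1)C2`: 300 mg/kg

In a functional assay on the whole organism (strain Swiss albino) with Mus musculus as the target, in the maximal electroshock model, with a stated time of 4 h (a lower number here means that less compound is needed, a higher number that more compound is needed for the effect), compound 2 stands level with compound 1 at the digits shown. Among the compounds with values here, the one measured step, no change at the digits printed from compound 1 to compound 2 (within the scatter), lay within the scatter.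

Compound 3, `COc1cc2c(cc1OC)C(=O)C(CC1CCN(C(=S)Nc3ccccc3Cl)CC1)C2`, differs from compound 2 by chloro in place of nitro on an aromatic carbon. Within the data shown here, that step has no direct precedent here; the only bearing step is the one from compound 1 to compound 2, which showed no change. No step beyond the scatter is therefore expected in this assay, and compound 3 is estimated at 300 mg/kg, range 150 mg/kg to 600 mg/kg, meaning an expected step of no change at the digits printed from compound 2 to compound 3 (within the scatter).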

Compound 3, minimum effective dose: 300 mg/kg
Beside the measured number, compound 3's estimate shows no gap at the digits printed, within the range that was stated.
By their numbers in this assay, from the lowest: compounds 1, 2 and 3 (each within the scatter of the next).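

In this assay chloro on the aromatic carbon ortho to a large group reads the same as nitro (no change at the digits printed from compound 2 to compound 3 (within the scatter)) and the same as hydrogen (no change at the digits printed from compound 1 to compound 3 (within the scatter)). This position now holds three different substituents, including a single chlorine atom as well as the larger nitro group, with no separation among them. Nothing available explains why these readings coincide.

The compounds shown leave open whether an amine or a carboxylic acid at this position would separate from them. From the compounds shown here alone, whether any replacement here can shift the minimum effective dose also remains open.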